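Sulfonamide series: from 4-iodophenyl to 3-bromophenyl

The source may report more compounds than this note shows. Statements on the series, on what has been measured and on what is new or still open speak of the compounds shown alone.

Measured in a functional assay on MCF7 cells (Homo sapiens) for antiproliferative activity, read by sulforhodamine B assay, with a stated time of 48 h; on this read-out higher numbers stand for weaker inhibition and lower numbers for stronger inhibition:
- compound 1 `Cc1ccc(NS(=O)(=O)c2ccc(N3CCNC3=O)cc2)cc1`: 610 nM
- compound 2 `O=C1NCCN1c1ccc(S(=O)(=O)Nc2ccc(F)cc2)cc1`: 690 nM
- compound 3 `O=C1NCCN1c1ccc(S(=O)(=O)Nc2ccc(I)cc2)cc1`: 600 nM

In this assay compound 3 gives 600 nM, which lies within the scatter of both other compounds, so the three values cannot be ranked. The next structure is compound 4 `O=C1NCCN1c1ccc(S(=O)(=O)Nc2cccc(Br)c2)cc1`, and the change is 3-bromophenyl in place of 4-iodophenyl on a sulfonamide nitrogen. In words, this is 3-bromophenyl in place of 4-iodophenyl on a sulfonamide nitrogen.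

The closest evidence comes from three measured steps. Fluoro in place of methyl on an aromatic carbon gives a 1.1-fold higher number from compound 1 to compound 2 (0.05 log units; within the scatter). Iodo in place of methyl gives a 1.0-fold lower number from compound 1 to compound 3 (0.01 log units; within the scatter), and iodo in place of fluoro gives a 1.2-fold lower number from compound 2 to compound 3 (0.06 log units; within the scatter). All three stay within the scatter, so these compounds show no sensitivity to that exchange. Going by the values given here, no bromo compound has been measured, and no measured step changes where the substituent sits on the ring, so that part of the change remains untested and the range is kept wide.

No shift beyond the scatter is expected in this assay, and the estimated step is a 1.1-fold higher number from compound 3 to compound 4 (0.03 log units; within the scatter). For compound 4 the expected value is 650 nM, with an estimated range from 300 nM to 1400 nM.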

Compound 4, half-maximal inhibitory concentration: 100 nM
Compound 4: the middle estimate sits 6.5-fold (0.81 log units) above what was measured, and the stated range ends above it.
By their numbers in this assay, from the lowest: compound 4; then compounds 3, 1 and 2 (each within the scatter of the next).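

In this assay the group on the sulfonamide nitrogen proves able to move the number well beyond the scatter, with a 6.0-fold lower number from compound 3 to compound 4 (0.78 log units; beyond the scatter), and the same holds against the other two aryl groups, with a 6.9-fold lower number from compound 2 to compound 4 (0.84 log units; beyond the scatter) and a 6.1-fold lower number from compound 1 to compound 4 (0.79 log units; beyond the scatter). The 4-methylphenyl, 4-fluorophenyl and 4-iodophenyl compounds had suggested a position indifferent to aryl substitution, but that flat picture holds only among these three, and compound 4 goes against it. No measurement shown offers an explanation for this step.

The compounds shown do not separate the halogen from its place on the ring: compound 4 is the only bromo compound and the only one whose substituent is not in the 4-position, so either change, or the two together, could account for the lower number. Also open, going by these compounds, is how this position responds to a phenyl substituent of another kind, such as an amine or a carboxylic acid, and whether the lower number carries over to those groups.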